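The source may report more compounds than this note shows. Statements on the series, on what has been measured and on what is new or still open speak of the compounds shown alone.

Among the measured compounds shown here, compound 2 `CNC(=O)CN1CC[C@H](n2c(Nc3ccccc3)nc3cnc(Nc4ccc(N5CCN(C)CC5)cc4)nc32)C1` gives the higher of the two numbers so far in a functional assay on HCC827 cells (Homo sapiens) for antiproliferative activity, read by MTT assay, with a stated time of 72 h; a lower number here means a stronger inhibitor, a higher number a weaker inhibitor: compound 2 shows 170 nM, whereas compound 1 `CN1CCN(c2ccc(Nc3ncc4nc(Nc5ccccc5)n([C@H]5CCN(S(C)(=O)=O)C5)c4n3)cc2)CC1` shows 17 nM. For the measured compounds named here, the one step measured, a 10-fold higher number from compound 1 to compound 2 (1.00 log units; beyond the scatter), is the only guide for the untested compound 3 `CC(=O)N1CC[C@H](n2c(Nc3ccccc3)nc3cnc(Nc4ccc(N5CCN(C)CC5)cc4)nc32)C1`, which differs from compound 2 by acetyl in place of (methylcarbamoyl)methyl on an amine nitrogen in a ring. Acetyl, like methylsulfonyl in compound 1, brings no hydrogen-bond donor, so a partial return toward the number of compound 1 is expected, with the step of a 3.8-fold lower number from compound 2 to compound 3 (0.58 log units; beyond the scatter) estimated. Compound 3 is therefore expected to give about 45 nM, in a range from 15 nM to 130 nM.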

Compound 3, half-maximal inhibitory concentration: 260 nM
The estimate for compound 3 lay 5.8-fold (0.76 log units) below the measured number; measured number outside the range, above it.
By their numbers in this assay, from the lowest: compound 1; then compounds 2 and 3 (each within the scatter of the next).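

In this assay, the step, a 1.5-fold higher number from compound 2 to compound 3 (0.18 log units; within the scatter), shows that losing the hydrogen-bond donor of (methylcarbamoyl)methyl does not by itself shift the number at this amine nitrogen in a ring. The step of a 15-fold higher number from compound 1 to compound 3 (1.18 log units; beyond the scatter) sets methylsulfonyl apart from acetyl at this place, so among these compounds the low number of compound 1 goes with methylsulfonyl and not simply with having no donor. Nothing available here gives a reason for this. From the compounds shown here alone, it remains open whether another sulfonyl group, such as ethylsulfonyl or phenylsulfonyl, would keep the low number of compound 1.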